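From Piperidin-1-yl to Anilino on the Chain of Compound 1

The compounds below may be only part of what the source reports. "The series", "measured", "known", "first", "only" and "open" are said of these compounds alone.

compound 1 `CC(C)=CCc1cc(C(=O)Nc2cc3ccc(OCCCN4CCCCC4)c(C)c3oc2=O)ccc1O`: > 50000 nM
compound 2 `CC(C)=CCc1cc(C(=O)Nc2cc3ccc(OCCCNC(C)C)c(C)c3oc2=O)ccc1O`: 750 nM
compound 3 `CC(C)=CCc1cc(C(=O)Nc2cc3ccc(OCCCN(C)C4CCCCC4)c(C)c3oc2=O)ccc1O`: 970 nM

In a functional assay on SK-BR-3 cells (Homo sapiens) for antiproliferative activity (a lower number here means a stronger inhibitor, a higher number a weaker inhibitor), compound 1 gives only a limit, > 50000 nM, and thus sits at the limit of > 50000 nM in this assay, at which 1 of the 3 values shown sits. Compound 2 gives 750 nM and compound 3 gives 970 nM. Both steps away from compound 1 are large: an at least 66-fold lower number from compound 1 to compound 2 (1.82 log units; beyond the scatter) and an at least 51-fold lower number from compound 1 to compound 3 (1.71 log units; beyond the scatter). Between the two, a 1.3-fold higher number from compound 2 to compound 3 (0.11 log units; within the scatter).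

Compound 4 `CC(C)=CCc1cc(C(=O)Nc2cc3ccc(OCCCNc4ccccc4)c(C)c3oc2=O)ccc1O` is not yet measured; it differs from compound 1 by anilino in place of piperidin-1-yl on a saturated chain carbon, three bonds along the chain from an oxygen on an aromatic ring. The two measured replacements of piperidin-1-yl at the same place each brought a large drop, though neither brought in an aromatic ring, so they bear on compound 4 only in part. A large decrease is nevertheless expected: an at least 25-fold lower number from compound 1 to compound 4 (1.39 log units; beyond the scatter). Compound 4 is estimated at 2000 nM, within a range from 300 nM to 25000 nM.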

Compound 4, half-maximal inhibitory concentration: > 50000 nM
Compound 4 was reported as a limit; the forecaster's own chance of this, stated with the estimate: 25%; at least 25-fold (1.39 log units) between middle value and limit.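

With anilino at this place, compound 4 is reported only as a limit, so replacing piperidin-1-yl here does not always give a measurable value in this assay: the limit of > 50000 nM in this assay, at which 2 of the 4 values shown sit.

What sits on the amine nitrogen matters greatly: phenyl in place of isopropyl gives an at least 66-fold higher number from compound 2 to compound 4 (1.82 log units; beyond the scatter), and anilino in place of cyclohexyl(methyl)amino gives an at least 51-fold higher number from compound 3 to compound 4 (1.71 log units; beyond the scatter). Compound 1 and compound 4 are both limits, and the step between them cannot be read.

On these data alone, it remains open whether benzylamino or morpholin-4-yl on the same chain would give a measurable value like compound 2 or a limit like compound 4.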